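The source may report more compounds than this note shows. Statements on the series, on what has been measured and on what is new or still open speak of the compounds shown alone.

Compound 1 `CC[C@@H]1C(=O)N(C)c2cnc(Nc3ccc(S(N)(=O)=O)cc3)nc2N1C1CCCC1` — 394 nM
Compound 2 `CCCCNC(=O)c1ccc2c(ccn2-c2ncc3c(n2)N(C2CCCC2)[C@H](CC)C(=O)N3C)c1` — 634 nM
Compound 3 `CCCNC(=O)c1ccc2c(ccn2-c2ncc3c(n2)N(c2ccn(C)n2)C(CC)C(=O)N3C)c1` — 6420 nM

All three were tested in a functional assay on MCF7 cells (Homo sapiens) for antiproliferative activity, read by CCK-8 assay, with a stated time of 72 h; a higher number here means a weaker inhibitor of growth, a lower number a stronger inhibitor of growth. Compound 1 gives the lowest number of the three. Compound 2 sits within the scatter of compound 1, so the two cannot be told apart. Compound 3 lies far beyond that scatter and is clearly a weaker growth inhibitor than compound 1.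

Compound 4 `CC[C@@H]1C(=O)N(C)c2cnc(Nc3ccc(S(=O)(=O)NC)cc3)nc2N1C1CCCC1` has not yet been measured. It differs from compound 1 in one place: methyl in place of hydrogen on a sulfonamide nitrogen; read one bond further out, amino becomes methylamino, sulfamoyl becomes methylsulfamoyl. Among the compounds with values here, no measured pair shows this change, so nothing measured guides the step. A small step of a 1.5-fold higher number from compound 1 to compound 4 (0.18 log units; within the scatter) is expected, toward a slightly higher number, not beyond the scatter. Compound 4 is expected to give 600 nM in this assay, with a range from 250 nM to 1500 nM.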

Compound 4, concentration for 50% growth inhibition: 151 nM
For compound 4 the middle estimate is 4.0-fold (0.60 log units) above the measured one; measured number outside the range, below it.
By their numbers in this assay, from the lowest: compound 4; then compounds 1 and 2 (each within the scatter of the next); then compound 3.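

In this assay, methyl in place of hydrogen on the sulfonamide nitrogen gives a 2.6-fold lower number from compound 1 to compound 4 (0.42 log units; beyond the scatter), so this position accepts a small carbon group and the number falls rather than rises. Growth inhibition by compound 1 therefore does not depend on that nitrogen keeping both of its hydrogens. Nothing shown here explains why the number falls. As far as these compounds go, whether a second methyl on the same nitrogen, a longer chain such as ethyl, or a small ring such as cyclopropyl would lower the number further remains open.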